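This account rests on a few compounds, and the source may have more. Where it says the series, first, only, none or still open, it means among the compounds named here.

Compound 1 `COc1cc2ncnc(NNC(=S)NC(=O)c3ccccc3Cl)c2cc1OC` and compound 2 `COc1cc2ncnc(NNC(=S)NC(=O)c3ccc(C)cc3)c2cc1OC` share one core; compound 3 `Cc1ccc(C(=O)NC(=S)NNc2ncnc3ccccc23)cc1` and compound 4 `O=C(NC(=S)NNc1ncnc2ccccc12)c1ccccc1Cl` share another. The difference between the two cores is not broken down here. In a functional assay on KB cells (Homo sapiens) for cytotoxicity, read by MTT assay, with a stated time of 72 h (on this read-out lower numbers stand for stronger inhibition and higher numbers for weaker inhibition), compound 2 gives 24200 nM, compound 1 gives 3560 nM and compound 3 gives 10100 nM. Compound 3 stands between the other two measured compounds, beyond the scatter on either side.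

Within the first core the change 2-chlorophenyl in place of 4-methylphenyl on a carbonyl carbon produced a 6.8-fold lower number from compound 2 to compound 1 (0.83 log units; beyond the scatter). The change 2-chlorophenyl in place of 4-methylphenyl on a carbonyl carbon is the same, made on the same place, and it occurs nowhere else among the compounds in hand, so one earlier step is all there is to rest on.

That earlier step was a 6.8-fold lower number from compound 2 to compound 1 (0.83 log units; beyond the scatter), and the expectation is that a step of the same direction but somewhat smaller size follows, since the step is seen once only. A step of a 4.0-fold lower number from compound 3 to compound 4 (0.61 log units; beyond the scatter) is expected for compound 4. Starting from the measured number of compound 3, compound 4 is expected to give about 2500 nM, most likely between 1000 nM and 7000 nM.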

Compound 4, half-maximal inhibitory concentration: 7710 nM
For compound 4 the middle estimate is 3.1-fold (0.49 log units) below the measured one, and the stated range ends below it.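

The change to 2-chlorophenyl in place of 4-methylphenyl on a carbonyl carbon gives a 1.3-fold lower number from compound 3 to compound 4 (0.12 log units; within the scatter) in this assay and so shows no shift beyond the scatter on the core of compound 3. The clear step on the core of compound 1 therefore cannot be carried over to the core of compound 3 as a fixed amount, although this single pair of cores neither explains the gap nor gives a rule for any further core. The two steps differ in size, so the change does not transfer unaltered between these cores: the same change on two cores in this assay, a 6.8-fold lower number (0.83 log units; beyond the scatter) from compound 2 to compound 1 and a 1.3-fold lower number (0.12 log units; within the scatter) from compound 3 to compound 4, 5.2-fold (0.72 log units) apart, beyond the scatter of two such steps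

Only 2-chlorophenyl and 4-methylphenyl stand on the carbonyl carbon here, so the comparison rests on one pair of groups on two cores. As far as these compounds go, whether an amine, a carboxylic acid or a longer chain in that place would also act differently on the two cores remains open, as does the contribution of the difference between the cores themselves.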